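The source may hold more compounds than are shown below. What is called first, only, known or untested is meant among the compounds shown, and "the series" means these compounds.

For the measured compounds named here, in a functional assay on BGC-823 cells (Homo sapiens) for antiproliferative activity, read by MTT assay, with a stated time of 48 h (on this read-out higher numbers stand for weaker inhibition and lower numbers for stronger inhibition), compound 1 `CCn1cc(-c2ccc(F)cc2)c(=O)c2cc(F)c(N3CCNCC3)cc21` gives 69600 nM, the highest of the two numbers so far, while compound 2 `CCn1cc(-c2ccc(C#N)cc2)c(=O)c2cc(F)c(N3CCNCC3)cc21` gives 18700 nM. Compound 3 `CCn1cc(-c2cccc(OC)c2)c(=O)c2cc(F)c(N3CCNCC3)cc21` differs from compound 1 by 3-methoxyphenyl in place of 4-fluorophenyl on an aromatic carbon, which is 3-methoxyphenyl in place of 4-fluorophenyl on an aromatic carbon. Going by the values given here, one measured step bears on this only loosely: a 3.7-fold lower number from compound 1 to compound 2 (0.57 log units; beyond the scatter), from cyano in place of fluoro. A smaller step to a lower number is therefore expected in this assay, possibly none beyond the scatter. For compound 3 the estimated value is 45000 nM, with an expected range of 18000 nM to 110000 nM. The estimate means an expected 1.5-fold lower number from compound 1 to compound 3 (0.19 log units; within the scatter).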

Compound 3, half-maximal inhibitory concentration: 14700 nM
Compound 3: the middle estimate sits 3.1-fold (0.49 log units) above what was measured; measured number outside the range, below it.
By their numbers in this assay, from the lowest: compounds 3 and 2 (each within the scatter of the next); then compound 1.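

At this aromatic carbon, a second replacement of 4-fluorophenyl also lowers the number in this assay (a 4.7-fold lower number from compound 1 to compound 3 (0.68 log units; beyond the scatter)), so the change is no longer tied to 4-cyanophenyl alone. The two replacements cannot be told apart (a 1.3-fold lower number from compound 2 to compound 3 (0.10 log units; within the scatter)), although 3-methoxyphenyl and 4-cyanophenyl carry different groups at different places on the phenyl ring. No measurement at hand accounts for the shift.

As far as these compounds go, whether the group or its place on the ring matters more stays open, and 4-methoxyphenyl would separate the two. Also open, from the compounds shown here alone, is what an aminophenyl or a carboxyphenyl group would give at this carbon.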